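The source may report more compounds than this note shows. Statements on the series, on what has been measured and on what is new or still open speak of the compounds shown alone.

Values so far in a functional assay on A549 cells (Homo sapiens) for antiproliferative activity, read by MTT assay, with a stated time of 48 h (on this read-out lower numbers stand for stronger inhibition and higher numbers for weaker inhibition), are as follows

compound 1 `Cc1ccc(Nc2ccc3c(c2)/C(=C\C2CCCCC2)C(=O)N3)cc1` gives 28200 nM
compound 2 `CC(C)CCC1C(=O)Nc2ccc(Nc3ccc(Cl)cc3)cc21` gives 2000 nM
compound 3 `CCCCCC1(O)C(=O)Nc2ccc(Nc3ccc(OC)cc3)cc21` gives 8000 nM

Compound 3 stands in the middle of the three numbers, and its gaps to the other two both lie beyond the scatter. Compound 1 has the higher number and compound 2 the lower. Among the compounds with values here, these three compounds differ in more than one place, so no measured step isolates a single change.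

Next in line is compound 4 `COc1ccc(Nc2ccc3c(c2)C(O)(Cc2ccccc2)C(=O)N3)cc1` with phenyl in place of butyl on a saturated chain carbon bound to a saturated ring carbon and the same difference, cut one bond further out, reads pentyl to benzyl. Within the data shown here, no measured pair tests this change, so the expectation rests on compound 3 at 8000 nM as the closest measured structure. In this assay no shift beyond the scatter is expected, and the estimated step is a 1.3-fold lower number from compound 3 to compound 4 (0.12 log units; within the scatter) towards a slightly lower number. For compound 4 the estimated value is 6000 nM with an expected range from 2200 nM to 16000 nM on this read-out.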

Compound 4, half-maximal inhibitory concentration: > 30000 nM
Compound 4: a limit, no number; the forecaster's own chance of this, stated with the estimate: 5%; middle value at least 5.0-fold (0.69 log units) from the limit.
By their numbers in this assay, from the lowest: compound 2; then compound 3; then compound 1. At a limit, above all of these: compound 4.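

Within the data shown here, this is the first pair that differs in one place: on a saturated chain carbon bound to a saturated ring carbon, phenyl in place of butyl gives an at least 3.7-fold higher number from compound 3 to compound 4 (0.57 log units; beyond the scatter) in this assay. The aromatic ring therefore does not act as a neutral replacement for the butyl part of the pentyl chain in this hydroxyl-bearing pair, and benzyl is the less favourable of the two side chains here. Compound 4 gives > 30000 nM, which is a limit and not a number, so the full size of the step remains unknown: the limit of > 30000 nM in this assay, at which 1 of the 4 values shown sits.

Going by these compounds, it remains open whether a saturated chain longer than pentyl, such as hexyl, would stay close to compound 3 or move towards compound 4. On these data alone, it is also open whether an amine on the benzyl ring would change the outcome, and whether the same change has a similar effect without the hydroxyl group.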